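The compounds below may be only part of what the source reports. "The series", "measured", "known", "first", "only" and "open" are said of these compounds alone.

Compound 1 `O=C(COc1ccc2cc(/C=C3/SC(=O)NC3=O)ccc2c1)Nc1ccccc1` gave 2100 nM in an assay on isolated protein for inhibition of histone deacetylase 4 (Homo sapiens), with a stated time of 1 h; on this read-out lower numbers stand for stronger inhibition and higher numbers for weaker inhibition.
Compound 2 `COc1ccc(NC(=O)COc2ccc3cc(/C=C4/SC(=O)NC4=O)ccc3c2)cc1` gave 4700 nM in this assay.
Compound 3 `Cc1cc(NC(=O)COc2ccc3cc(/C=C4/SC(=O)NC4=O)ccc3c2)no1` gave 1700 nM in this assay.

Compound 3 has the lowest of the three numbers, but its separation from compound 1 is within the scatter a 1.2-fold lower number from compound 1 to compound 3 (0.09 log units; within the scatter), and only its separation from compound 2 is beyond it a 2.8-fold lower number from compound 2 to compound 3 (0.44 log units; beyond the scatter). Compound 4 `O=C(COc1ccc2cc(/C=C3/SC(=O)NC3=O)ccc2c1)Nc1cc(Cl)cc(C(F)(F)F)c1` has not yet been measured; it differs from compound 3 by 3-chloro-5-(trifluoromethyl)phenyl in place of 5-methyl-1,2-oxazol-3-yl on an amide-type nitrogen. Among the measured compounds shown here, two measured steps bear on this change. Replacing phenyl with the five-membered ring made no difference beyond the scatter a 1.2-fold lower number from compound 1 to compound 3 (0.09 log units; within the scatter), while adding a methoxy group to the phenyl amide gave a modest weakening a 2.2-fold higher number from compound 1 to compound 2 (0.35 log units; beyond the scatter). A substituted phenyl amide is therefore expected to sit close to compound 3, perhaps slightly higher, so a step of a 1.5-fold higher number from compound 3 to compound 4 (0.17 log units; within the scatter) is estimated, which would stay within the scatter. Compound 4 is expected to give about 2500 nM in this assay, with a likely range from 900 nM to 7000 nM.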

Compound 4, half-maximal inhibitory concentration: 4000 nM
For compound 4 the middle estimate is 1.6-fold (0.20 log units) below the measured one, within the range that was stated.
By their numbers in this assay, from the lowest: compounds 3, 1, 4 and 2 (each within the scatter of the next, the first and the last beyond it).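

Compound 4 is a second substituted phenyl amide that lies beyond the scatter from the 5-methyl-1,2-oxazol-3-yl amide, with a 2.4-fold higher number from compound 3 to compound 4 (0.37 log units; beyond the scatter). The two substituted phenyl amides cannot be told apart, with a 1.2-fold lower number from compound 2 to compound 4 (0.07 log units; within the scatter), and the added chloro and trifluoromethyl groups do not separate compound 4 from the unsubstituted phenyl amide, with a 1.9-fold higher number from compound 1 to compound 4 (0.28 log units; within the scatter), unlike the methoxy group of compound 2. Nothing at hand accounts for these results.

Chloro and trifluoromethyl enter together here, so the share of each on the phenyl ring remains open. Also open, on these data alone, is whether an amine or a carboxylic acid on that ring, or a longer chain in place of the ring on the amide-type nitrogen, would shift the number in this assay beyond the scatter.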